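Aryl change on the aromatic nitrogen of compound 2

This account rests on a few compounds, and the source may have more. Where it says the series, first, only, none or still open, it means among the compounds named here.

Going by the values given here, in a functional assay on MCF7 cells (Homo sapiens) for inhibition, read by MTT assay, with a stated time of 72 h (a lower number here means a stronger inhibitor, a higher number a weaker inhibitor), compound 2 `Cc1ccc(-n2c(-c3coc4cc(C)c(Cl)cc4c3=O)nc(-c3ccccc3)c2-c2ccccc2)cc1` gives 12500 nM, the higher of the two numbers so far. Among the compounds with values here, its only neighbour is compound 1 `Cc1cc2occ(-c3nc(-c4ccccc4)c(-c4ccccc4)n3-c3ccccc3Cl)c(=O)c2cc1Cl`, which gives 3120 nM. Within the data shown here, the one measured step at this aromatic nitrogen is a 4.0-fold higher number from compound 1 to compound 2 (0.60 log units; beyond the scatter), a modest change beyond the scatter, with 4-methylphenyl in place of 2-chlorophenyl.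

Compound 3 `COc1cccc(-n2c(-c3coc4cc(C)c(Cl)cc4c3=O)nc(-c3ccccc3)c2-c2ccccc2)c1` carries 3-methoxyphenyl in place of 4-methylphenyl on the same nitrogen: 3-methoxyphenyl in place of 4-methylphenyl on an aromatic nitrogen. Among the measured compounds shown here, that single step shows that the group here can shift the number, but no measured compound carries a methoxy group, so it gives only a rough scale. With compound 2 at the top of a two-point range, any movement is expected to be toward a lower number, and no larger than the measured step. The expected change is a 1.6-fold lower number from compound 2 to compound 3 (0.19 log units; within the scatter). For compound 3 the estimate is 8000 nM, with an expected range of 3000 nM to 20000 nM.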

Compound 3, half-maximal inhibitory concentration: 25000 nM
For compound 3 the middle estimate is 3.1-fold (0.49 log units) below the measured one; measured number outside the range, above it.
By their numbers in this assay, from the lowest: compound 1; then compounds 2 and 3 (each within the scatter of the next).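

In this assay, the exchange on the aromatic nitrogen gives a 2.0-fold higher number from compound 2 to compound 3 (0.30 log units; within the scatter) and does not separate the two compounds, so 3-methoxyphenyl, with its one hydrogen-bond acceptor, and 4-methylphenyl read alike here. Compound 1 now stands apart from both, with an 8.0-fold higher number from compound 1 to compound 3 (0.90 log units; beyond the scatter) beside the earlier 4.0-fold higher number from compound 1 to compound 2 (0.60 log units; beyond the scatter), so 2-chlorophenyl is the only group shown at this nitrogen with the lower number, a pattern resting on that single compound. Nothing available gives a reason for this gap.

Going by these compounds, it remains open whether the chlorine itself or its place on the phenyl ring accounts for compound 1, which a 4-chlorophenyl or a 2-methylphenyl group would test. Also open, on these data alone, is how a benzyl group or a plain alkyl chain on this nitrogen would read.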